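Chloro for Methoxy on Two Related Triazine Scaffolds

The compounds below may be only part of what the source reports. "The series", "measured", "known", "first", "only" and "open" are said of these compounds alone.

Compound 1 `COc1ccc(N2CCN(CC(=O)N3CCN(c4nnc(-c5ccccc5)c(-c5ccccc5)n4)CC3)CC2)cc1` carries a methoxy group, and in a functional assay on MCF7 cells (Homo sapiens) for cytotoxicity, read by MTT assay, with a stated time of 24 h (a higher number here means a weaker inhibitor, a lower number a stronger inhibitor), compound 1 reaches only a limit, > 910000 nM. Compound 2 `O=C(CN1CCN(c2ccc(Cl)cc2)CC1)N1CCN(c2nnc(-c3ccccc3)c(-c3ccccc3)n2)CC1` makes one change, (chloro in place of methoxy on an aromatic carbon), and gives 56300 nM in this assay, a step of an at least 16-fold lower number from compound 1 to compound 2 (1.20 log units; beyond the scatter). The size of that step rests on the limit reached by compound 1 (the limit of > 910000 nM in this assay, at which 1 of the 3 values shown sits). Compound 3 `COc1ccc(N2CCN(CC(=O)N3CCN(c4nnc(-c5ccc(C)cc5)c(-c5ccc(C)cc5)n4)CC3)CC2)cc1` keeps the methoxy on another core; how the two cores differ is not broken down here. In this assay compound 3 gives 53000 nM, within the scatter of compound 2. Compound 4 `Cc1ccc(-c2nnc(N3CCN(C(=O)CN4CCN(c5ccc(Cl)cc5)CC4)CC3)nc2-c2ccc(C)cc2)cc1` is not yet measured and makes the same change on the core of compound 3, (chloro in place of methoxy on an aromatic carbon). Compound 4 is expected to give 20000 nM in this assay, between 5000 nM and 80000 nM. That estimate means a step of a 2.7-fold lower number from compound 3 to compound 4 (0.42 log units; beyond the scatter), kept smaller than the earlier one because an at least 16-fold lower number from compound 1 to compound 2 (1.20 log units; beyond the scatter) starts from a limit.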

Compound 4, half-maximal inhibitory concentration: 660000 nM
The estimate for compound 4 lay 33-fold (1.52 log units) below the measured number, and the stated range ends below it.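

In this assay the change from 4-methoxyphenyl to 4-chlorophenyl gives a 12-fold higher number from compound 3 to compound 4 (1.10 log units; beyond the scatter) on this core, the opposite direction to the earlier step. The change therefore does not carry over from one core to the other in this pair of cores, in direction or in size: the same change on two cores in this assay, an at least 16-fold lower number (1.20 log units; beyond the scatter) from compound 1 to compound 2 and a 12-fold higher number (1.10 log units; beyond the scatter) from compound 3 to compound 4, at least 200-fold (2.30 log units) apart, beyond the scatter of two such steps. Going by these compounds, the earlier step rests on a limit, that of compound 1, so its exact size remains unknown, and these compounds do not show what causes the reversal: the limit of > 910000 nM in this assay, at which 1 of the 4 values shown sits.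

The compounds shown leave open whether fluoro or a nitrile in that place would follow compound 2 or compound 4 on either core. They also leave open which direction the change would take on a third core.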